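Ester to acid on a purine series

The source may hold more compounds than are shown below. What is called first, only, known or untested is meant among the compounds shown, and "the series" means these compounds.

Measured so far:
compound 1 `O=C(O)C[C@H](NC(=O)CN(c1nc(Cl)nc2[nH]cnc12)C1CC1)C(=O)O`: 11.6%
compound 2 `CC(C)C[C@H](NC(=O)CN(c1nc(Cl)nc2[nH]cnc12)C1CC1)C(=O)OCc1ccccc1`: 5.26%

Two compounds have been run in a functional assay on the whole organism (Tail, strain ICR) with Mus musculus as the target, in the tail flick test, with a stated time of 150 min, at a dose of 25 umol/kg by the oral route; a lower number here means a weaker effect, a higher number a stronger effect of the compound at the dose given. Compound 1 `O=C(O)C[C@H](NC(=O)CN(c1nc(Cl)nc2[nH]cnc12)C1CC1)C(=O)O` gives 11.6% in this assay. Compound 2 `CC(C)C[C@H](NC(=O)CN(c1nc(Cl)nc2[nH]cnc12)C1CC1)C(=O)OCc1ccccc1` gives 5.26% in this assay. The two numbers lie within the usual scatter of one another, so nothing separates compound 2 from compound 1 on the numbers shown; both sit at the low end of the read-out.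

Compound 3 `CC(C)C[C@H](NC(=O)CN(c1nc(Cl)nc2[nH]cnc12)C1CC1)C(=O)O` has not been measured. It differs from compound 2 by hydrogen in place of benzyl on an oxygen next to a carbonyl group. For the measured compounds named here, no step between two measured compounds describes this change, so the size of its effect is not known from this series.

Given that compound 1 gives 11.6% as a free acid and compound 2 gives 5.26% as an ester, the step of a number 4.7 percentage points higher from compound 2 to compound 3 (within the scatter) is expected to stay within the scatter. Compound 3 is estimated at 10%, with a range from 0% to 25%.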

Compound 3, a percentage reported as activity, at one dose (the size of the read-out at that dose, not a potency): 9.13%
Estimate against measurement, compound 3: 0.9 percentage points above; measured number inside the range.
By their numbers in this assay, from the lowest: compounds 2, 3 and 1 (each within the scatter of the next).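

With hydrogen in place of benzyl on an oxygen next to a carbonyl group, this assay shows a number 3.9 percentage points higher from compound 2 to compound 3 (within the scatter), so this change does not separate the benzyloxycarbonyl and carboxy forms. With isopropyl in place of carboxy on a saturated chain carbon, two bonds along the chain from an amide-type nitrogen and a carbonyl carbon, this assay shows a number 2.5 percentage points lower from compound 1 to compound 3 (within the scatter), so this second change also leaves the numbers unseparated. Nothing available bears on the reason for either result.

Going by these compounds, whether a methyl or ethyl ester on that oxygen would give a number beyond the scatter remains open. The same holds for an amine or a longer chain on that saturated chain carbon.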